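Methoxy in place of pyridinyloxy: tolerance expected unchanged

The source may report more compounds than this note shows. Statements on the series, on what has been measured and on what is new or still open speak of the compounds shown alone.

The series shares the core shown in compound 1 `CCc1nc2ccccc2n1CCCOc1ccccc1`, an ether-linked chain ending in an aromatic ring. In an ADME assay on Vero cells (Chlorocebus sabaeus) for cytotoxicity, read by luminescence, with a stated time of 2 days (a higher number here means that more compound is tolerated, a lower number that less compound is tolerated), compound 1 is reported only as the limit > 50 uM. Compound 2 `CCc1nc2ccccc2n1CCCCOc1ccc(Cl)cc1F`, whose chain ends in 4-chloro-2-fluorophenyl, gives 5.7 uM in this assay. Compound 3 `CCc1nc2ccccc2n1CCCCOc1ccncc1` is reported in this assay only as the limit > 50 uM. Within the data shown here, the one measured step touching the chain end is an at least 8.7-fold higher number from compound 2 to compound 3 (0.94 log units; beyond the scatter). Compound 3 thus stands at the limit of > 50 uM in this assay, at which 2 of the 3 values shown sit. Compound 4 `CCc1nc2ccccc2n1CCCCOC` differs from compound 3 by methyl in place of pyridin-4-yl on an oxygen on a saturated carbon. No measured step exchanges an aromatic end group for a plain alkyl group, so there is no direct precedent for this change in this assay, and nothing among the shown values points toward a lower number for a smaller end group. The expected step that the limit leaves unreadable from compound 3 to compound 4 is therefore none beyond the scatter. Compound 4 is estimated at 60 uM in this assay, within 25 uM to 150 uM, most likely reported again as a limit.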

Compound 4, half-maximal toxic concentration: > 50 uM
Compound 4 was reported as a limit; the forecaster's own chance of this, stated with the estimate: 70%; the middle value is on the limit's open side.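

In this assay compound 4 gives > 50 uM, which is a limit. Methyl in place of 4-chloro-2-fluorophenyl on the oxygen gives an at least 8.7-fold higher number from compound 2 to compound 4 (0.94 log units; beyond the scatter), so this position need not carry an aromatic ring for the reading to sit at the limit, as pyridin-4-yl alone had shown so far. The steps to compound 4 from compound 3 and from compound 1 cannot be read, and only compound 2 stands off the limit: the limit of > 50 uM in this assay, at which 3 of the 4 values shown sit.

The compounds shown do not tell whether the chloro or the fluoro substituent of 4-chloro-2-fluorophenyl goes with the lower number of compound 2, nor how compound 3 and compound 4 compare beyond the limit. As far as these compounds go, what an amine or a carboxylic acid at this chain end, or a longer alkyl chain on the oxygen, would give in this assay also stays open.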